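A Saturated Ring in Place of an Aromatic One

The source may hold more compounds than are shown below. What is called first, only, known or untested is meant among the compounds shown, and "the series" means these compounds.

Measured compounds:
compound 1, `CSc1ccc2c(Cc3cccc(C(=O)O)n3)c(-c3ccccc3)nn2c1`, 87 nM
compound 2, `O=C(O)c1cccc(Cc2c(-c3cccs3)nn3cc(Cl)ccc23)n1`, 1100 nM

Of the compounds shown here, two have been measured in a functional assay on cells for antagonist activity at prostaglandin E2 receptor EP1 subtype (Rattus norvegicus), read by fluorescence and calcium flux, with a stated time of 60 s; on this read-out lower numbers stand for stronger inhibition and higher numbers for weaker inhibition. Compound 1 `CSc1ccc2c(Cc3cccc(C(=O)O)n3)c(-c3ccccc3)nn2c1` gives 87 nM in this assay. Compound 2 `O=C(O)c1cccc(Cc2c(-c3cccs3)nn3cc(Cl)ccc23)n1` gives 1100 nM in this assay, which is the higher of the two numbers; compound 1 sits a long way below it, and that gap is well beyond the usual scatter. Among the measured compounds shown here, the two structures differ in more than one place, so no single step between them is recorded.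

Compound 3 `O=C(O)c1cccc(Cc2c(N3CCCCC3)nn3cc(Cl)ccc23)n1` has not yet been measured. It is built from compound 2 by one change: piperidin-1-yl in place of thiophen-2-yl on an aromatic carbon. For the measured compounds named here, nothing measured so far speaks to this particular exchange, since no pair among the measured compounds differs only here. The account therefore rests on compound 2 alone. In this assay compound 3 is expected to land close to compound 2, with a step of a 1.4-fold higher number from compound 2 to compound 3 (0.13 log units; within the scatter) that is not expected to exceed the scatter, and the uncertainty is wide in both directions. The estimate for compound 3 is 1500 nM, expected to fall between 300 nM and 8000 nM.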

Compound 3, half-maximal inhibitory concentration: 79 nM
Compound 3: the middle estimate sits 19-fold (1.28 log units) above what was measured; the whole stated range lies above it.
By their numbers in this assay, from the lowest: compounds 3 and 1 (each within the scatter of the next); then compound 2.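

In this assay, piperidin-1-yl in place of thiophen-2-yl on this aromatic carbon gives a 14-fold lower number from compound 2 to compound 3 (1.14 log units; beyond the scatter) and this shows that the position does not need an aromatic ring: a six-membered non-aromatic ring, joined through its ring nitrogen, goes with much stronger inhibition than the five-membered aromatic ring of compound 2. The leaving and entering groups have the same count of hydrogen-bond donors, the same count of acceptors and no net charge, so those counts do not separate them, even though the step is large. Nothing available here accounts for the size of this step.

The compounds shown leave open whether the stronger inhibition follows from the saturated ring itself or from having a ring nitrogen attached to the aromatic carbon, a question that cyclohexyl in the same place would address. They also leave open how much room the position allows around the ring nitrogen, as pyrrolidin-1-yl and morpholin-4-yl would test, and whether the same exchange would hold on the core of compound 1.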